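Aryl piperazine variation on a shared core: compound 4

A few compounds are considered here, and "the series" means these few. Any claim that something is new, unique, unknown or untested is made for them only; others in the source may bear on it.

Measured compounds:
compound 1 `Nc1scc(CN2CCN(c3ccc(Cl)cc3Cl)CC2)c1C(=O)c1ccc(Cl)cc1` — -54%
compound 2 `Nc1scc(CN2CCN(c3ccc(Cl)cc3F)CC2)c1C(=O)c1ccc(Cl)cc1` — -57%
compound 3 `Nc1scc(CN2CCN(c3ccc(Cl)c(C(F)(F)F)c3)CC2)c1C(=O)c1ccc(Cl)cc1` — -47%

In a functional assay on CHO cells with adenosine receptor A1 (Homo sapiens) as the target, read by cAMP accumulation and immunoassay, with a stated time of 6 min, tested at 1 uM (on this read-out higher numbers stand for a weaker effect at the one concentration tested and lower numbers for a stronger effect), compound 3 gives the highest of the three numbers, but it lies within the scatter of both neighbours: a number 7 percentage points higher from compound 1 to compound 3 (within the scatter) and a number 10 percentage points higher from compound 2 to compound 3 (within the scatter). The remaining step, a number 3 percentage points lower from compound 1 to compound 2 (within the scatter), is likewise within the scatter, so the three measured compounds show no separation on this read-out.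

Compound 4 `Nc1scc(CN2CCN(c3cccc4ccccc34)CC2)c1C(=O)c1ccc(Cl)cc1` differs from compound 3 by naphthalen-1-yl in place of 4-chloro-3-(trifluoromethyl)phenyl on an amine nitrogen in a ring. Going by the values given here, none of the measured steps changes the group on the ring nitrogen to anything resembling a naphthalen-1-yl; all three steps exchange one substituted phenyl for another, and all three stayed within the scatter. On that basis compound 4 is expected to sit near compound 3, with a step of a number 3 percentage points lower from compound 3 to compound 4 (within the scatter) that is not expected to exceed the scatter. Among the compounds with values here, the estimate for compound 4 in this assay is -50%, with a range from -72% to -28%, the width reflecting that no measured step covers a change of this kind.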

Compound 4, a percentage reported as activity, at one concentration (the size of the read-out at that concentration, not a potency): 2.9%
For compound 4 the middle estimate is 52.9 percentage points below the measured one; the whole stated range lies below it.
By their numbers in this assay, from the lowest: compounds 2, 1 and 3 (each within the scatter of the next); then compound 4.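

In this assay, the group on the ring nitrogen proves to be a place where the read-out can move a long way: naphthalen-1-yl gives a number 49.9 percentage points higher from compound 3 to compound 4 (beyond the scatter), and likewise a number 59.9 percentage points higher from compound 2 to compound 4 (beyond the scatter) and a number 56.9 percentage points higher from compound 1 to compound 4 (beyond the scatter). Going by these compounds alone, the earlier exchanges among halogen-bearing phenyl groups had all stayed within the scatter, so this is the first change at this position to separate two compounds, and compound 4 stands apart from all three others. Nothing measured here accounts for the size of this step.

This one change brings in a second six-membered aromatic ring and removes all the halogens, so the compounds shown cannot tell which of the two matters. Also open, on these data alone, is how an unsubstituted phenyl or a naphthalen-2-yl on the same ring nitrogen would read.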